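The source may report more compounds than this note shows. Statements on the series, on what has been measured and on what is new or still open speak of the compounds shown alone.

Compound 1 `O=C(/C=C/c1cccc(NC(=O)c2ccccc2Br)c1)c1nc2ccccc2[nH]1` is one of two amides built on the same core. In a functional assay on HCT-116 cells (Homo sapiens) for antiproliferative activity, read by MTT assay, with a stated time of 48 h (a lower number here means a stronger inhibitor, a higher number a weaker inhibitor), compound 1 gives 1680 nM, while compound 2 `O=C(Nc1cccc(/C=C/C(=O)c2nc3ccccc3[nH]2)c1)c1cccc(C(F)(F)F)c1` gives 3360 nM; the step of a 2.0-fold higher number from compound 1 to compound 2 (0.30 log units; within the scatter) lies within the scatter, so the two numbers are not separated. Compound 3 `O=C(/C=C/c1cccc(NS(=O)(=O)c2ccccc2Cl)c1)c1nc2ccccc2[nH]1` differs from compound 1 in one place: (2-chlorophenyl)sulfonyl in place of (2-bromophenyl)carbonyl on a nitrogen on an aromatic ring. Within the data shown here, no measured step exchanges the carbonyl link itself, and the only step known, from compound 1 to compound 2, stays within the scatter. For compound 3 a step of a 1.2-fold higher number from compound 1 to compound 3 (0.08 log units; within the scatter) is therefore expected, with no change beyond the scatter, and compound 3 is estimated at 2000 nM, between 600 nM and 7000 nM.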

Compound 3, half-maximal inhibitory concentration: 987 nM
Compound 3: the middle estimate sits 2.0-fold (0.31 log units) above what was measured, within the range that was stated.
By their numbers in this assay, from the lowest: compounds 3, 1 and 2 (each within the scatter of the next, the first and the last beyond it).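

The link on the nitrogen on an aromatic ring can be exchanged without separating the two compounds (a 1.7-fold lower number from compound 1 to compound 3 (0.23 log units; within the scatter)) in this assay. The earlier step changed only the aryl group on a carbonyl carbon, whereas this one shows that a sulfonyl link is tolerated at this place in the core of compound 1. Nothing available here bears on this result.

As far as these compounds go, the sulfonyl link and the chlorine enter together, so their separate contributions remain open. Also open, from the compounds shown here alone, is how compound 3 would respond to an amine or a carboxylic acid on its phenyl ring.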